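The source may report more compounds than this note shows. Statements on the series, on what has been measured and on what is new or still open speak of the compounds shown alone.

Measured compounds:
compound 1 `CCCc1c(COc2ccc(C(=O)Cc3nnn[nH]3)cc2)ccc(C(C)=O)c1O`: 7.71
compound 2 `CCCc1c(COc2ccc(C(=O)C(C)Cc3nnn[nH]3)cc2)ccc(C(C)=O)c1O`: 7.18

Going by the values given here, in a functional assay on ileum (Cavia porcellus) with cysteinyl leukotriene receptor (Homo sapiens) as the target (a lower number here means a less potent compound, a higher number a more potent compound, by a factor of ten per unit of this negative logarithm), compound 1 gives 7.71, the higher of the two numbers measured so far; the only other step known is a number 0.53 log units lower from compound 1 to compound 2 (beyond the scatter). Compound 3 `CCCc1c(COc2ccc(C(=O)C(C)(C)Cc3nnn[nH]3)cc2)ccc(C(C)=O)c1O` differs from compound 1 by 1-((1H-tetrazol-5-yl)methyl)-1-methylethyl in place of (1H-tetrazol-5-yl)methyl on a carbonyl carbon. The step of a number 0.53 log units lower from compound 1 to compound 2 (beyond the scatter) bears directly on this change, since there a single added methyl on the carbonyl carbon already lowered the number. Adding a second methyl is expected to push the same way, probably somewhat further, by a number 1.01 log units lower from compound 1 to compound 3 (beyond the scatter). Compound 3 is therefore estimated at 6.7, within a range of 6.1 to 7.3.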

Compound 3, negative logarithm of the antagonist equilibrium constant: 6.93
The estimate for compound 3 lay 0.23 log units below the measured number; the range from low to high includes it.
By their numbers in this assay, from the lowest: compounds 3 and 2 (each within the scatter of the next); then compound 1.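

In this assay, two methyls on the saturated chain carbon bound to the carbonyl carbon give a number 0.78 log units lower from compound 1 to compound 3 (beyond the scatter) and so the drop seen with one methyl holds for a second compound. Adding the second methyl gives a number 0.25 log units lower from compound 2 to compound 3 (within the scatter) and so compounds 2 and 3 cannot be told apart, while compound 1 stays the most potent of the three. No available evidence explains this drop. Still open, from the compounds shown here alone, is whether an ethyl group or a hydroxyl group on that carbon would match methyl, and how a longer chain would compare.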